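The compounds below may be only part of what the source reports. "The series", "measured", "known", "first", "only" and "open" are said of these compounds alone.

Compound 1 `CCc1cnc(N2CCC(n3nnc4cc(-c5ccc(S(C)(=O)=O)cc5F)ncc43)CC2)nc1`: 7 nM
Compound 2 `CCNC(=O)c1ccc(-c2cc3nnn(C4CCN(c5ncc(CC)cn5)CC4)c3cn2)c(F)c1`: 15 nM

In a functional assay on HEK293 cells for agonist activity at Glucose-dependent insulinotropic receptor (Homo sapiens), read by HTRF and cAMP accumulation, with a stated time of 30 min (on this read-out higher numbers stand for an effect only at larger amounts of compound and lower numbers for an effect already at smaller amounts), compound 2 stands at the higher of the two numbers, with a 2.1-fold higher number from compound 1 to compound 2 (0.33 log units; beyond the scatter) separating it from compound 1. Compound 3 `CCNC(=O)c1ccc(-c2cc3nnn(C4CCN(c5ncc(CC)cn5)CC4)c3cn2)c(C(F)(F)F)c1` is not yet measured. It differs from compound 2 by trifluoromethyl in place of fluoro on an aromatic carbon. Among the compounds with values here, the only measured step exchanges the ethylcarbamoyl group for methylsulfonyl and does not touch this position, so no measured step bears directly on the change. The expectation is a modest step, a 2.0-fold higher number from compound 2 to compound 3 (0.30 log units; within the scatter), and compound 3 is estimated at 30 nM, with a range from 8 nM to 120 nM.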

Compound 3, half-maximal effective concentration: 60 nM
Compound 3: the middle estimate sits 2.0-fold (0.30 log units) below what was measured; the measured number falls inside the stated range.
By their numbers in this assay, from the lowest: compound 1; then compound 2; then compound 3.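

Within the data shown here, the step to trifluoromethyl in place of fluoro gives a 4.0-fold higher number from compound 2 to compound 3 (0.60 log units; beyond the scatter) in this assay and is the first measured change at this position, so what sits here does affect the number. The change adds heavy atoms but no hydrogen-bond donors or acceptors, and the higher number goes with trifluoromethyl in this single pair. Nothing available explains the shift. From the compounds shown here alone, whether hydrogen, chloro or methoxy at this position would give a lower or higher number stays open. So does whether this change would have the same effect with methylsulfonyl in place of the ethylcarbamoyl group.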